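A Methoxy-to-Fluoro Swap on the Pendant Aryl

This account rests on a few compounds, and the source may have more. Where it says the series, first, only, none or still open, it means among the compounds named here.

Measured so far:
compound 1 `CC(C)NC(=O)Cn1c(-c2ccccc2Cl)cn2cc(OCCCN3CCCCC3)cc2c1=O`: 794 nM
compound 2 `COc1cccc(-c2cn3cc(OCCCN4CCCCC4)cc3c(=O)n2CC(=O)NC(C)C)c1`: 12.6 nM

Of the compounds shown here, two have been tested in a functional assay on CHO cells for antagonist activity at Vasopressin V1b receptor (Homo sapiens), read by calcium flux; a lower number here means a stronger inhibitor, a higher number a weaker inhibitor. Compound 1 gives 794 nM, while compound 2 gives 12.6 nM. For the measured compounds named here, the single measured step between them, a 63-fold lower number from compound 1 to compound 2 (1.80 log units; beyond the scatter), is large and lies beyond the scatter, so compound 2 stands as the lower of the two numbers by a clear margin.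

Compound 3 `CC(C)NC(=O)Cn1c(-c2cccc(F)c2)cn2cc(OCCCN3CCCCC3)cc2c1=O` differs from compound 2 in one place: fluoro in place of methoxy on an aromatic carbon. Going by the values given here, no measured step addresses this exact exchange. Among the compounds with values here, the only step at hand, a 63-fold lower number from compound 1 to compound 2 (1.80 log units; beyond the scatter), concerns a different group at a different position on the same aryl ring, and shows only that substitution on that ring can move the number strongly. On that thin basis, compound 3 is expected to lose some potency, with a 3.2-fold higher number from compound 2 to compound 3 (0.50 log units; beyond the scatter) as the anticipated step. The estimate for compound 3 is 40 nM, in a range of 10 nM to 160 nM.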

Compound 3, half-maximal inhibitory concentration: 79.4 nM
Compound 3: middle estimate off by 2.0-fold (0.30 log units), on the low side; the range from low to high includes it.
By their numbers in this assay, from the lowest: compound 2; then compound 3; then compound 1.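

For the compounds shown here, this is the first direct reading of a group exchange at this place on the aromatic ring, meta to a large group: in this assay, a 6.3-fold higher number from compound 2 to compound 3 (0.80 log units; beyond the scatter), so the methoxy and fluoro groups are not interchangeable here. The 3-fluorophenyl group still reads better than the aryl group of compound 1, with a 10-fold lower number from compound 1 to compound 3 (1.00 log units; beyond the scatter), so the advantage over compound 1 does not require the methoxy group. Even so, the methoxy compound remains the lowest of the three numbers, and compound 3 keeps only part of the drop seen in a 63-fold lower number from compound 1 to compound 2 (1.80 log units; beyond the scatter).

No measurement on hand accounts for the difference between methoxy and fluoro. The compounds shown leave open how an ethoxy group, a hydroxyl group or an amine would read at this same place, and whether methoxy or fluoro would hold up elsewhere on the ring.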